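Reverting the oxadiazole orientation with a methyl substituent

A few compounds are considered here, and "the series" means these few. Any claim that something is new, unique, unknown or untested is made for them only; others in the source may bear on it.

Measured so far:
- compound 1 `CCCN(CCC)C[C@@H](C)NC(=O)c1ccc(-c2noc(C(F)F)n2)cc1`: 890 nM
- compound 2 `CCCN(CCC)C[C@@H](C)NC(=O)c1ccc(-c2nc(C(F)(F)F)no2)cc1`: 28000 nM

In an assay on isolated protein for inhibition of histone deacetylase 4 (Homo sapiens), read by fluorescence (a lower number here means a stronger inhibitor, a higher number a weaker inhibitor), compound 2 stands highest of the two numbers; its nearest neighbour is compound 1, and the gap a 31-fold higher number from compound 1 to compound 2 (1.50 log units; beyond the scatter) is large. Compound 3 `CCCN(CCC)C[C@@H](C)NC(=O)c1ccc(-c2noc(C)n2)cc1` is not yet measured. It differs from compound 2 by 5-methyl-1,2,4-oxadiazol-3-yl in place of 3-(trifluoromethyl)-1,2,4-oxadiazol-5-yl on an aromatic carbon. Within the data shown here, the only step that bears on this is a 31-fold higher number from compound 1 to compound 2 (1.50 log units; beyond the scatter), which swapped the ring orientation and the fluorinated group together; compound 3 restores the orientation of compound 1 but carries a methyl, for which no measurement exists. A drop in the number toward compound 1 is therefore expected, though with wide uncertainty. For compound 3 the expected step is a 14-fold lower number from compound 2 to compound 3 (1.15 log units; beyond the scatter), giving an estimate of 2000 nM with a range of 600 nM to 8000 nM.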

Compound 3, half-maximal inhibitory concentration: > 50000 nM
Compound 3 gave a limit, no number; the forecaster's own chance of this, stated with the estimate: 5%; middle value at least 25-fold (1.39 log units) away from the limit.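

In this assay compound 3 gives > 50000 nM, which is a limit of the assay and not a number. Exchanging difluoromethyl for methyl, with the ring orientation unchanged, gives an at least 56-fold higher number from compound 1 to compound 3 (1.74 log units; beyond the scatter), so this orientation alone does not bring back the earlier strength, and the small group on the oxadiazole matters at this position. The change in both ring orientation and substituent reads an at least 1.7-fold higher number from compound 2 to compound 3 (0.25 log units; that floor lies within the scatter), a floor that cannot put these two compounds in order.

The compounds shown leave open what ring orientation does by itself. They also leave open whether a monofluoromethyl or an ethyl group on the same ring would fall nearer compound 1 or compound 3.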